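The compounds below may be only part of what the source reports. "The series", "measured", "known", "first", "only" and "open" are said of these compounds alone.

Measured so far in an ADME assay on Huh-5-2 cells (Homo sapiens) for cytotoxicity, read by WST assay, with a stated time of 3 days; on this read-out higher numbers stand for lower toxicity in this test and lower numbers for higher toxicity in this test:
compound 1 `Cc1ccccc1COc1c(-c2ccccc2)oc2cc(O)cc(O)c2c1=O` gives 55000 nM;
compound 2 `N#Cc1cccc(COc2c(-c3ccccc3)oc3cc(O)cc(O)c3c2=O)c1` gives 21000 nM;
compound 3 `COc1cccc(COc2c(-c3ccccc3)oc3cc(O)cc(O)c3c2=O)c1` gives 28000 nM.

Compound 3 stands second highest of the three numbers. Its gap to compound 2, a 1.3-fold higher number from compound 2 to compound 3 (0.12 log units; within the scatter), lies within the scatter, as does a 2.0-fold lower number from compound 1 to compound 3 (0.29 log units; within the scatter); only a 2.6-fold lower number from compound 1 to compound 2 (0.42 log units; beyond the scatter) reaches beyond it, and modestly. Compound 4 `N#Cc1ccc(COc2c(-c3ccccc3)oc3cc(O)cc(O)c3c2=O)cc1` differs from compound 3 by 4-cyanophenyl in place of 3-methoxyphenyl on a saturated chain carbon bound to an oxygen on an aromatic ring. The step that bears on this most directly is a 1.3-fold higher number from compound 2 to compound 3 (0.12 log units; within the scatter), which swapped methoxy for cyano on the ring and stayed within the scatter. A cyano-bearing ring in compound 4 is therefore expected to give a number close to that of compound 2, and the estimated step of a 1.3-fold lower number from compound 3 to compound 4 (0.10 log units; within the scatter) is not expected to exceed the scatter. Compound 4 is estimated at 22000 nM, within a range of 11000 nM to 45000 nM.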

Compound 4, half-maximal cytotoxic concentration: 48000 nM
Beside the measured number, compound 4's estimate is 2.2-fold (0.34 log units) below it; the whole stated range lies below it.
By their numbers in this assay, from the lowest: compounds 2, 3, 4 and 1 (each within the scatter of the next, the first and the last beyond it).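

In this assay, moving the nitrile matters: 4-cyanophenyl in place of 3-cyanophenyl gives (a 2.3-fold higher number from compound 2 to compound 4 (0.36 log units; beyond the scatter)), so two groups with the same atoms can be told apart at this position. The other two changes tell less, as both stay within the scatter (a 1.7-fold higher number from compound 3 to compound 4 (0.23 log units; within the scatter)) and (a 1.1-fold lower number from compound 1 to compound 4 (0.06 log units; within the scatter)). Nothing available explains the difference between the two nitrile-bearing rings. Still open, going by these compounds, is whether an amine or a carboxylic acid on this ring, or a longer chain in place of the ring, would move the number.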